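Oxetane amine to gem-dimethyl amine on the side chain

A few compounds are considered here, and "the series" means these few. Any claim that something is new, unique, unknown or untested is made for them only; others in the source may bear on it.

Compound 1 `Cc1ccc2nc(N3CCCc4ccc(F)cc4C3)cc(NCC3(N)COC3)c2c1` stands at the upper edge of the values shown. In an ADME assay on HEp-2 cells (Homo sapiens) for cytotoxicity, read by CCK-8 assay, with a stated time of 5 days (a higher number here means that more compound is tolerated, a lower number that less compound is tolerated), compound 1 gives > 100000 nM, which is a limit of the assay and not a number (the limit of > 100000 nM in this assay, at which 1 of the 3 values shown sits). Compound 2 `NC(=O)NCCNc1cc(N2CCc3ccccc3C2)nc2ccccc12` gives 80000 nM in this assay, and compound 3 `NCCNc1cc(N2CCCc3ccccc3C2)nc2ccccc12` gives 23000 nM. Compound 4 `Cc1ccc2nc(N3CCCc4ccc(F)cc4C3)cc(NCC(C)(C)N)c2c1` differs from compound 1 in one place: 1-amino-1-methylethyl in place of 3-aminooxetan-3-yl on a saturated chain carbon bound to a nitrogen on an aromatic ring. Going by the values given here, no measured pair in this set shows this change, so its effect is not known from the data. The account expects a small shift toward less tolerated compound, an at least 1.6-fold lower number from compound 1 to compound 4 (0.22 log units; that floor lies within the scatter), though it may lie within the scatter. Compound 4 is estimated at 60000 nM in this assay, with a range from 20000 nM to 100000 nM.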

Compound 4, half-maximal cytotoxic concentration: 23000 nM
Compound 4: the middle estimate sits 2.6-fold (0.42 log units) above what was measured; low and high end bracket the measured number.
By their numbers in this assay, from the lowest: compounds 3 and 4 (each within the scatter of the next); then compound 2. At a limit, above all of these: compound 1.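

In this assay, going by these compounds alone, the step for 1-amino-1-methylethyl in place of 3-aminooxetan-3-yl is an at least 4.3-fold lower number from compound 1 to compound 4 (0.63 log units; beyond the scatter) and it lies beyond the scatter, the first readable change at this position. The swap alone, on an otherwise unchanged core, thus moves the number clearly. How large the step truly is stays unknown, since compound 1 holds a limit of the assay and not a number: the limit of > 100000 nM in this assay, at which 1 of the 4 values shown sits.

The compounds shown leave open where an azetidine or a cyclobutane ring carrying the amine would fall on this side chain. They also leave open whether the same change would read alike on another core.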